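This account rests on a few compounds, and the source may have more. Where it says the series, first, only, none or still open, it means among the compounds named here.

Measured in a functional assay on MCF7 cells (Homo sapiens) for antiproliferative activity, read by MTT assay, with a stated time of 48 h (a lower number here means a stronger inhibitor, a higher number a weaker inhibitor), are three compounds
- compound 1 `O=C(/C=C/c1ccccc1)Nc1nnc(-c2ccccc2)s1` gives 1.47 ug/mL
- compound 2 `COc1ccc(/C=C/C(=O)Nc2nnc(-c3ccccc3)s2)cc1` gives 0.83 ug/mL
- compound 3 `Cc1ccc(/C=C/C(=O)Nc2nnc(-c3ccccc3)s2)cc1` gives 1.23 ug/mL

Compound 2, at 0.83 ug/mL, stands within the scatter of both other compounds. Compound 4 `COc1ccc(/C=C/C(=O)Nc2nnc(-c3ccc(Cl)cc3)s2)cc1` differs from it by chloro in place of hydrogen on an aromatic carbon, the change from phenyl to 4-chlorophenyl. Going by the values given here, no measured step makes this change. The closest evidence is substitution elsewhere on the molecule, with methoxy in place of hydrogen (a 1.8-fold lower number from compound 1 to compound 2 (0.25 log units; within the scatter)) and methyl in place of hydrogen (a 1.2-fold lower number from compound 1 to compound 3 (0.08 log units; within the scatter)), both within the scatter. In this assay no step beyond the scatter is therefore expected, and no direction is favoured. The expected step is small (a 1.0-fold lower number from compound 2 to compound 4 (0.02 log units; within the scatter)). Compound 4 is estimated at 0.8 ug/mL (expected range 0.35 ug/mL to 1.8 ug/mL).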

Compound 4, half-maximal inhibitory concentration: 0.91 ug/mL
Compound 4: the middle estimate sits 1.1-fold (0.06 log units) below what was measured; the measured number falls inside the stated range.
By their numbers in this assay, from the lowest: compounds 2, 4, 3 and 1 (each within the scatter of the next).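

Going by these compounds alone, compound 1, compound 2 and compound 3 all carry the same unsubstituted phenyl, so compound 4 gives the first reading at this position: in this assay, the change to 4-chlorophenyl gives a 1.1-fold higher number from compound 2 to compound 4 (0.04 log units; within the scatter). With methoxy kept in place, this position therefore takes chloro without a step beyond the scatter. No measurement bearing on this result accompanies the compounds.

On these data alone, whether an amine or a carboxylic acid at this place would give a step beyond the scatter remains open. The compounds shown also do not tell whether chloro would give a similar step without the methoxy group.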